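A few compounds are considered here, and "the series" means these few. Any claim that something is new, unique, unknown or untested is made for them only; others in the source may bear on it.

Series notes. Compound 1 `C#CCCOC(=O)C1=C(C)NC(C)=C(C(=O)OC)C1c1cccc([N+](=O)[O-])c1` gives 35 nM in a functional assay on HEK293 cells for antagonist activity at Voltage-dependent L-type calcium channel subunit alpha-1D (Rattus norvegicus), read by FLIPR; a higher number here means a weaker inhibitor, a lower number a stronger inhibitor; compound 2 `CCCCCOC(=O)C1=C(C)NC(C)=C(C(=O)OCC)C1c1cccc([N+](=O)[O-])c1` gives 130 nM and compound 3 `C=C(C)C(=O)OCCOC(=O)C1=C(C)NC(C)=C(C(=O)OCC)C1c1cccc([N+](=O)[O-])c1` gives 10 nM, so compound 1 stands second highest of the three numbers, between the other two. Among the compounds with values here, the only single-point step on record, a 13-fold lower number from compound 2 to compound 3 (1.11 log units; beyond the scatter), shows that an exchange on an ester chain can move the read-out a great deal, but it concerns a different group at a different place. Compound 4 `COC(=O)C1=C(C)NC(C)=C(C(=O)OCc2ccccc2)C1c1cccc([N+](=O)[O-])c1` differs from compound 1 by phenyl in place of propargyl on a saturated chain carbon bound to an oxygen next to a carbonyl group. Within the data shown here, no measured step bears directly on this exchange, so the step of no change at the digits printed from compound 1 to compound 4 (within the scatter) is expected to stay within the scatter, with no direction favoured. For compound 4 a value of 35 nM is estimated, with a range from 9 nM to 140 nM.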

Compound 4, half-maximal inhibitory concentration: 15 nM
For compound 4 the middle estimate is 2.3-fold (0.37 log units) above the measured one, and the stated range covers the measured number.
By their numbers in this assay, from the lowest: compounds 3 and 4 (each within the scatter of the next); then compound 1; then compound 2.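

In this assay, the exchange of propargyl for phenyl on a saturated chain carbon bound to an oxygen next to a carbonyl group gives a 2.3-fold lower number from compound 1 to compound 4 (0.37 log units; beyond the scatter). Within the data shown here, the step is modest, but it is the first direct reading at this place, and it shows that an aromatic ring of six carbons is accepted there with a stronger read-out than the triple-bond chain. As far as these compounds go, whether a longer chain, an amine or a substituted benzyl at the same place would move the number further stays open. Nothing available gives a reason for this shift.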